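A few compounds are considered here, and "the series" means these few. Any claim that something is new, unique, unknown or untested is made for them only; others in the source may bear on it.

Compound 2, `CN(C)C(=O)Nc1cccc(-c2ccc(N(C)C)cc2)c1`, stands highest of the two numbers in an assay on COS-7 cells for inhibition of patatin-like phospholipase domain-containing protein 2 (Mus musculus), tested at 200 uM; a higher number here means more inhibition at the concentration tested (going by the name of the read-out), a lower number less inhibition: in this assay compound 2 gives 98%, while compound 1, `CN(C)c1ccc(-c2cccc([N+](=O)[O-])c2)cc1`, gives 21%, so that the step of a number 77 percentage points higher from compound 1 to compound 2 (beyond the scatter) lies well beyond the scatter. Compound 3, `COC(=O)Nc1cccc(-c2ccc(N(C)C)cc2)c1`, has not yet been measured. It differs from compound 2 at one place: methoxy in place of dimethylamino on a carbonyl carbon. Among the compounds with values here, the single measured step, from nitro to (dimethylcarbamoyl)amino on an aromatic carbon, concerns a different place and does not bear directly on this exchange; nothing measured here tells what methoxy in place of dimethylamino on a carbonyl carbon does. The (methoxycarbonyl)amino group keeps the amide-type nitrogen and the carbonyl of compound 2, so the expectation is a step of a number 13 percentage points lower from compound 2 to compound 3 (beyond the scatter), within or near the scatter, downward if anything. Compound 3 is therefore estimated at 85%, between 55% and 100%.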

Compound 3, a percentage reported as inhibition, at one concentration (the size of the read-out at that concentration, not a potency): 95%
Compound 3: middle estimate off by 10 percentage points, on the low side; the measured number falls inside the stated range.
By their numbers in this assay, from the lowest: compound 1; then compounds 3 and 2 (each within the scatter of the next).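

In this assay, methoxy in place of dimethylamino on a carbonyl carbon gives a number 3 percentage points lower from compound 2 to compound 3 (within the scatter), so the read-out does not distinguish these two groups at this place. The step in place of nitro also holds for a second group, with a number 74 percentage points higher from compound 1 to compound 3 (beyond the scatter), which shows that the large gain seen earlier is not confined to (dimethylcarbamoyl)amino. No measurement at hand accounts for this result. Going by these compounds, whether a plain amine on the aromatic carbon in place of nitro, or ethoxy or a longer alkoxy chain on the carbonyl carbon, would keep the number this high remains open. On these data alone, since the read-out comes from a single concentration, it also remains open whether compound 2 and compound 3 would separate at lower concentrations.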